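The source may report more compounds than this note shows. Statements on the series, on what has been measured and on what is new or still open speak of the compounds shown alone.

Three compounds sharing one core were examined in a functional assay on HCT-116 cells (Homo sapiens) for inhibition, read by MTT assay, with a stated time of 72 h; on this read-out lower numbers stand for stronger inhibition and higher numbers for weaker inhibition. Compound 1 `COc1cc2c(Oc3ccc(NC(=O)c4nn(-c5ccccc5)ccc4=O)cc3)ccnc2cc1OCCCC(=O)NO` gives 940 nM in this assay. Compound 3 `COc1cc2c(Oc3ccc(NC(=O)c4nn(-c5ccccc5C)ccc4=O)cc3)ccnc2cc1OCCCCCC(=O)NO` gives 700 nM. Compound 2 `COc1cc2c(Oc3ccc(NC(=O)c4nn(-c5ccccc5)cc(C)c4=O)cc3)ccnc2cc1OCCCCCCC(=O)NO` gives the lowest of the three numbers, 150 nM; its nearest neighbour is compound 3 and its furthest is compound 1, and both gaps lie beyond the usual scatter, so compound 2 stands as the most potent of the measured set. Compounds 1 and 3 lie within the scatter of each other, and no order between them is claimed.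

Compound 4 `COc1cc2c(Oc3ccc(NC(=O)c4nn(-c5ccc(C)cc5)cc(C)c4=O)cc3)ccnc2cc1OCCCCCCC(=O)NO` has not yet been measured. It differs from compound 2 in a single place: methyl in place of hydrogen on an aromatic carbon. For the measured compounds named here, no pair of measured compounds isolates this change, so nothing in the data shows how the added methyl moves the read-out in this assay. A change this small, a single carbon added to an aromatic carbon, is expected to leave the number close to that of compound 2, and the expected step of a 1.1-fold higher number from compound 2 to compound 4 (0.03 log units; within the scatter) is small, in no firm direction, and not beyond the scatter. Compound 4 is therefore estimated at 160 nM in this assay, with a range from 60 nM to 450 nM.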

Compound 4, half-maximal inhibitory concentration: 400 nM
Estimate against measurement, compound 4: 2.5-fold (0.40 log units) below, within the range that was stated.
By their numbers in this assay, from the lowest: compound 2; then compounds 4, 3 and 1 (each within the scatter of the next, the first and the last beyond it).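

For the compounds shown here, the pair of compound 2 and compound 4 is the first in the set to isolate a single change, and in this assay going from phenyl to 4-methylphenyl gives a modest step (a 2.7-fold higher number from compound 2 to compound 4 (0.43 log units; beyond the scatter)). Going by these compounds alone, the read-out at this position, on an aromatic carbon para to a large group, is therefore not indifferent to one added carbon: here methyl in place of hydrogen goes with weaker inhibition, which the earlier compounds could not show. Nothing measured in this set accounts for the direction or size of the step.

From the compounds shown here alone, what remains open is whether this step is particular to methyl or would also appear with another group at the same place, such as chlorine, methoxy, an amine or a carboxylic acid. It is also unknown whether the same change would move the number similarly on the shorter chain of compound 1, and compound 3, which carries its methyl elsewhere on the phenyl ring and differs in more than one place, cannot settle either question.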